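Replacing the Methoxy Group on the Saturated Ring

A few compounds are considered here, and "the series" means these few. Any claim that something is new, unique, unknown or untested is made for them only; others in the source may bear on it.

Compound 2 `COC1(c2cc(F)cc(OCc3ccc(-n4ccnc4C)cc3)c2)CCOCC1` is the starting point of this step. Within the data shown here, in an assay on blood for inhibition of Polyunsaturated fatty acid 5-lipoxygenase (Homo sapiens) (on this read-out higher numbers stand for weaker inhibition and lower numbers for stronger inhibition), compound 2 gives 60 nM, the lowest of the three numbers measured so far. Its two measured neighbours share the same core but carry a different group on the saturated ring carbon: compound 1 `Cc1nccn1-c1ccc(COc2cc(F)cc(C3(C(N)=O)CCOCC3)c2)cc1` bears a carbamoyl group and gives 340 nM, while compound 3 `CCOC(=O)C1(c2cc(F)cc(OCc3ccc(-n4ccnc4C)cc3)c2)CCOCC1` bears an ethoxycarbonyl group and gives 200 nM. Compound 4 `Cc1nccn1-c1ccc(COc2cc(F)cc(C3([S+](C)[O-])CCOCC3)c2)cc1` has not yet been measured; its change from compound 2 is a group of 3 heavy atoms (1 carbon, 1 oxygen, 1 sulfur; no ring) in place of a group of 2 heavy atoms (1 carbon, 1 oxygen; no ring), on a saturated ring carbon. Two measured steps alter the group on that same ring carbon and so bear on this change: a 5.7-fold lower number from compound 1 to compound 2 (0.75 log units; beyond the scatter) and a 3.3-fold higher number from compound 2 to compound 3 (0.52 log units; beyond the scatter). In both, the methoxy compound gave the lower number, while a 1.7-fold lower number from compound 1 to compound 3 (0.23 log units; within the scatter) lies within the scatter. Swapping the methoxy group for anything else has so far raised the number by a modest amount, and the step to compound 4 is expected to behave alike: a 3.3-fold higher number from compound 2 to compound 4 (0.52 log units; beyond the scatter). Compound 4 is therefore expected to give 200 nM in this assay, with a range from 70 nM to 600 nM.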

Compound 4, half-maximal inhibitory concentration: > 1000 nM
Compound 4: only a limit was reported; the forecaster's own chance of this, stated with the estimate: 3%; at least 5.0-fold (0.69 log units) between middle value and limit.
By their numbers in this assay, from the lowest: compound 2; then compounds 3 and 1 (each within the scatter of the next). At a limit, above all of these: compound 4.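

In this assay, compound 4 does not give a number, only a limit of the assay: the limit of > 1000 nM in this assay, at which 1 of the 4 values shown sits. Swapping methoxy for this sulfur-bearing group on the saturated ring carbon gives an at least 16-fold higher number from compound 2 to compound 4 (1.22 log units; beyond the scatter), a large step, whereas the earlier steps away from methoxy were modest. The new group also falls behind the other two groups at this carbon, with an at least 5.0-fold higher number from compound 3 to compound 4 (0.69 log units; beyond the scatter) and an at least 2.9-fold higher number from compound 1 to compound 4 (0.46 log units; beyond the scatter), making compound 4 the weakest inhibitor of the four.

Going by these compounds, since only a limit is available, the true size of these steps stays unknown. The compounds shown also leave open whether the sulfur atom itself matters and whether a hydroxyl, an amine or a plain methyl on this carbon would match methoxy.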